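This account rests on a few compounds, and the source may have more. Where it says the series, first, only, none or still open, it means among the compounds named here.

Compound 1 `CC[C@H](C)[C@H](NC(=O)c1cccc(Cn2ccnc2)c1)C(=O)Nc1nccs1`: 42000 nM
Compound 2 `CCCCS(=O)(=O)NNC(=O)[C@@H](NC(=O)c1cccc(Cn2ccnc2)c1)[C@@H](C)CC`: > 100000 nM
Compound 3 `CC[C@H](C)[C@H](NC(=O)c1cccc(Cn2ccnc2)c1)C(=O)NS(=O)(=O)c1ccccc1`: 18000 nM

All three compounds share one core and were tested in an assay on HEK293 cells for displacement of a labelled ligand from Type-2 angiotensin II receptor (Homo sapiens); on this read-out lower numbers stand for stronger inhibition and higher numbers for weaker inhibition. The value given for compound 2 is a limit of the assay and not a number, (the limit of > 100000 nM in this assay, at which 1 of the 3 values shown sits). Compound 2 therefore stands at the weakest end of the measured set, with its true number unknown beyond that limit.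

Compound 4 `CC[C@H](C)[C@H](NC(=O)c1cccc(Cn2ccnc2)c1)C(=O)NNS(=O)(=O)c1c(C)cc(C)cc1C` differs from compound 2 in one place: 2,4,6-trimethylphenyl in place of butyl on a sulfonyl sulfur. Among the compounds with values here, two measured steps bear on this. First, an at least 5.5-fold lower number from compound 2 to compound 3 (0.74 log units; beyond the scatter), the only step that leaves compound 2. Second, a 2.3-fold lower number from compound 1 to compound 3 (0.37 log units; beyond the scatter). Both steps end at compound 3, the compound that carries an aromatic ring on its sulfonyl sulfur, and both run toward lower numbers. Compound 4 also carries an aromatic ring on its sulfonyl sulfur, while keeping the sulfonamide nitrogen of compound 2. In this assay a modest move toward lower numbers is therefore expected, an at least 2.8-fold lower number from compound 2 to compound 4 (0.45 log units; beyond the scatter). Compound 4 is estimated at 35000 nM, within a range from 12000 nM to 100000 nM.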

Compound 4, inhibition constant: 8500 nM
Compound 4: middle estimate off by 4.1-fold (0.61 log units), on the high side; the measured number lies below the stated range.
By their numbers in this assay, from the lowest: compound 4; then compound 3; then compound 1. At a limit, above all of these: compound 2.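

The earlier steps shown here replaced the whole group on the amide-type nitrogen, whereas this one changes only the group on the sulfonyl sulfur and keeps the sulfonamide nitrogen in place. In this assay, replacing butyl with 2,4,6-trimethylphenyl at this position gives an at least 11-fold lower number from compound 2 to compound 4 (1.07 log units; beyond the scatter), so this one site alone can carry a large change in the read-out. Compound 2 has a limit of the assay and not a number, so the true step could be larger still: the limit of > 100000 nM in this assay, at which 1 of the 4 values shown sits.

The compounds shown leave open whether the aromatic ring itself or its methyl groups account for the change, and they cannot say why either would matter. A benzyl group or a longer chain such as octyl on this sulfur would help to separate these possibilities.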